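Replacing the 4-cyclopropylphenyl group of compound 3

A few compounds are considered here, and "the series" means these few. Any claim that something is new, unique, unknown or untested is made for them only; others in the source may bear on it.

In a functional assay on HOS-TE85 cells (Homo sapiens) for inhibition, read by CCK-8 assay, with a stated time of 72 h (on this read-out lower numbers stand for stronger inhibition and higher numbers for weaker inhibition), compound 1 `Cc1cccc(N2C(=O)CSC2c2cccc(C(=O)NCCCCc3ccccc3)c2)c1` gives 93.2 nM and compound 2 `O=C(NCCCCc1ccccc1)c1cccc(C2SCC(=O)N2c2cccc(F)c2)c1` gives 32.4 nM while compound 3 `O=C(NCCCCc1ccccc1)c1cccc(C2SCC(=O)N2c2ccc(C3CC3)cc2)c1` stands highest of the three at 217 nM on this read-out. Compound 4 `O=C(NCCCCc1ccccc1)c1cccc(C2SCC(=O)N2c2nccs2)c1` carries 1,3-thiazol-2-yl in place of 4-cyclopropylphenyl on an amide-type nitrogen in a ring. Two measured steps change the group on that same nitrogen, namely a 2.3-fold higher number from compound 1 to compound 3 (0.37 log units; beyond the scatter) and a 6.7-fold higher number from compound 2 to compound 3 (0.83 log units; beyond the scatter) (both modest), and each ends at 4-cyclopropylphenyl. Leaving that group may therefore give back part of such a rise, though no five-membered aromatic group has been measured there. The expected step in this assay is modest and toward a lower number (a 2.2-fold lower number from compound 3 to compound 4 (0.34 log units; beyond the scatter)). Compound 4 is expected at 100 nM (estimated range 30 nM to 330 nM).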

Compound 4, half-maximal inhibitory concentration: > 1000 nM
Compound 4: only a limit was reported (the forecaster's own chance of this, stated with the estimate: 3%); at least 10-fold (1.00 log units) between middle value and limit.
By their numbers in this assay, from the lowest: compound 2; then compound 1; then compound 3. At a limit, above all of these: compound 4.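

Compound 4 is reported only as a limit in this assay: the limit of > 1000 nM in this assay, at which 1 of the 4 values shown sits. Even so, the steps are readable as minimum sizes: an at least 4.6-fold higher number from compound 3 to compound 4 (0.66 log units; beyond the scatter), an at least 10-fold higher number from compound 1 to compound 4 (1.03 log units; beyond the scatter) and an at least 30-fold higher number from compound 2 to compound 4 (1.48 log units; beyond the scatter). The substituted phenyl groups on the amide-type nitrogen in a ring thus differ among themselves by much less than the largest of these steps, and 1,3-thiazol-2-yl is the first group shown there to reach the limit. The compounds shown leave open whether this rise follows the five-membered ring or its nitrogen and sulfur atoms. Thiophen-2-yl or pyridin-2-yl on that nitrogen would help separate the two.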